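This account rests on a few compounds, and the source may have more. Where it says the series, first, only, none or still open, it means among the compounds named here.

Compound 1, `COC(=O)C1=C(C)N=C(C)/C(=C(\O)OC)C1c1cc(Cl)cc(Cl)c1`, is the reference point of this small set. In a functional assay (muscle tissue) with Cavia porcellus as the target (a higher number here means that more compound is needed for the effect, a lower number that less compound is needed), compound 1 gives 93.3 nM, the lowest of the three numbers recorded, and its nearest neighbour is compound 2, `COC(=O)C1=C(C)N=C(C)/C(=C(\O)OC)C1c1ccc(F)cc1`, which in this assay gives 129 nM; the step of a 1.4-fold higher number from compound 1 to compound 2 (0.14 log units; within the scatter) lies within the scatter. The furthest is compound 3, `COC(=O)C1=C(C)N=C(C)/C(=C(\O)OC)C1c1ccc(I)cc1`, which in this assay gives 22900 nM, so that a 250-fold higher number from compound 1 to compound 3 (2.39 log units; beyond the scatter), and a 180-fold higher number from compound 2 to compound 3 (2.25 log units; beyond the scatter).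

Compound 4, `COC(=O)C1=C(C)N=C(C)/C(=C(\O)OC)C1c1cccc(Br)c1`, differs from compound 1 in one place: 3-bromophenyl in place of 3,5-dichlorophenyl on a saturated ring carbon. Within the data shown here, two measured steps bear on this change, both starting from compound 1 and both replacing the 3,5-dichlorophenyl by a phenyl bearing a single halogen: the step to 4-fluorophenyl stayed within the scatter, while the step to 4-iodophenyl was large. Neither step tests a 3-bromophenyl, so the direct evidence is thin. Because a 1.4-fold higher number from compound 1 to compound 2 (0.14 log units; within the scatter) shows that losing one chlorine and moving to a single halogen need not cost anything, compound 4 is expected to stay close to compound 1, with a 1.2-fold higher number from compound 1 to compound 4 (0.07 log units; within the scatter) as the expected step. The estimate for compound 4 in this assay is therefore 110 nM, within a range from 30 nM to 450 nM.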

Compound 4, half-maximal effective concentration: 1.29 nM
For compound 4 the middle estimate is 85-fold (1.93 log units) above the measured one; the whole stated range lies above it.
By their numbers in this assay, from the lowest: compound 4; then compounds 1 and 2 (each within the scatter of the next); then compound 3.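

In this assay, among these compounds, the saturated ring carbon that carries the aryl group proves able to move the number strongly downward, and not only upward as the earlier compounds showed: replacing the 3,5-dichlorophenyl by 3-bromophenyl gives a 72-fold lower number from compound 1 to compound 4 (1.86 log units; beyond the scatter), which makes compound 4 the lowest of the four. Carrying a single halogen on the phenyl does not by itself fix the outcome, for compounds 2, 3 and 4 all do so and yet the set now holds a 100-fold lower number from compound 2 to compound 4 (2.00 log units; beyond the scatter) as well as an 18000-fold lower number from compound 3 to compound 4 (4.25 log units; beyond the scatter), the latter being the widest gap among these compounds. Nothing shown here offers a measured explanation for the size of these steps.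

The compounds shown do not separate the identity of the halogen from where it sits on the phenyl, since compound 4 differs from compounds 2 and 3 in both respects at once. They also leave open how the number would respond to a phenyl carrying an amine, a carboxylic acid or a methoxy group in place of the halogen, and whether the low number of compound 4 would hold for a phenyl with no halogen at all.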